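Amino for Methyl on the Aryl Ring of Compound 2

A few compounds are considered here, and "the series" means these few. Any claim that something is new, unique, unknown or untested is made for them only; others in the source may bear on it.

Measured so far:
- compound 1, `Cc1cccc(-c2cc(C)cc(C(=O)Nc3nn[nH]n3)n2)c1`: 51%
- compound 2, `Cc1ccc(-c2cc(C)cc(C(=O)Nc3nn[nH]n3)n2)cc1`: 80%

For the measured compounds named here, in a functional assay on the whole organism with Rattus norvegicus as the target, at a dose of 1 mg/kg by the oral route (on this read-out lower numbers stand for a weaker effect and higher numbers for a stronger effect at the one dose given), compound 2 gives the higher of the two numbers, and the only step measured, a number 29 percentage points higher from compound 1 to compound 2 (beyond the scatter), is a move of the methyl on the phenyl ring. Compound 3, `Cc1cc(C(=O)Nc2nn[nH]n2)nc(-c2ccc(N)cc2)c1`, differs from compound 2 by amino in place of methyl on an aromatic carbon. Going by the values given here, no measured step exchanges one group for another on this ring, so the single step gives no direct guide. Compound 3 is therefore expected to stay near compound 2, with a number 8 percentage points lower from compound 2 to compound 3 (within the scatter) as the estimated step, not beyond the scatter. The estimate for compound 3 is 72%, ranging from 45% to 95%.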

Compound 3, a percentage reported as inhibition, in the whole organism at one dose (the size of the read-out at that dose, not a potency): 75%
Beside the measured number, compound 3's estimate is 3 percentage points below it; low and high end bracket the measured number.
By their numbers in this assay, from the lowest: compound 1; then compounds 3 and 2 (each within the scatter of the next).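

In this assay, for the compounds shown here, amino in place of methyl gives a number 5 percentage points lower from compound 2 to compound 3 (within the scatter) so at this place, para to a large group, the first exchange of one group for another leaves the number within the usual scatter. The 4-aminophenyl group also shows a number 24 percentage points higher from compound 1 to compound 3 (beyond the scatter) and so, like 4-methylphenyl, stands clear of 3-methylphenyl. No evidence is available to explain either step. On these data alone, whether a carboxylic acid, a methoxy group or a longer chain would hold the effect at this place remains open. So does how amino would behave in the place of the methyl in compound 1.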